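Stripping the Alkyl Group from a Kinase Inhibitor Series

A few compounds are considered here, and "the series" means these few. Any claim that something is new, unique, unknown or untested is made for them only; others in the source may bear on it.

For the measured compounds named here, compound 2 `CC(C)c1cc(-c2nn(C(C)C)c3ncnc(N)c23)no1` gives 2400 nM in an assay on BaF3 cells for inhibition of proto-oncogene tyrosine-protein kinase receptor Ret (Homo sapiens), read by MTT assay, with a stated time of 48 h (on this read-out higher numbers stand for weaker inhibition of growth and lower numbers for stronger inhibition of growth), the higher of the two numbers recorded so far, though its only neighbour, compound 1 `CCc1cc(-c2nn(C(C)C)c3ncnc(N)c23)no1`, which gives 1560 nM in this assay, sits within the scatter of it. Going by the values given here, the single measured step, a 1.5-fold higher number from compound 1 to compound 2 (0.19 log units; within the scatter), shows that adding a methyl to the saturated chain did not move the number beyond the scatter. Compound 3 `CC(C)n1nc(-c2ccon2)c2c(N)ncnc21` has not yet been measured; it differs from compound 2 as follows: hydrogen in place of isopropyl on an aromatic carbon. Among the compounds with values here, the step of a 1.5-fold higher number from compound 1 to compound 2 (0.19 log units; within the scatter) is the only one that bears on this change, and it speaks only to growing the chain, not to removing it altogether; no measured pair shows a bare hydrogen at that position. The step of a 1.0-fold higher number from compound 2 to compound 3 (0.02 log units; within the scatter) is therefore expected to stay small, with wide uncertainty. Compound 3 is estimated at 2500 nM in this assay, within a range of 900 nM to 7000 nM.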

Compound 3, concentration for 50% growth inhibition: 3210 nM
Compound 3: the middle estimate sits 1.3-fold (0.11 log units) below what was measured; measured number inside the range.
By their numbers in this assay, from the lowest: compounds 1, 2 and 3 (each within the scatter of the next, the first and the last beyond it).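

For the compounds shown here, compound 3 is the first here with hydrogen rather than an alkyl group on the aromatic carbon next to the ring oxygen. In this assay, going by these compounds alone, replacing isopropyl with hydrogen gives a 1.3-fold higher number from compound 2 to compound 3 (0.13 log units; within the scatter), so this change does not clear the scatter, whereas replacing ethyl with hydrogen gives a 2.1-fold higher number from compound 1 to compound 3 (0.31 log units; beyond the scatter), the first step to pass it, though only modestly. No independent evidence bears on these numbers.

The compounds shown leave open whether an amine, a carboxylic acid or a longer chain on this aromatic carbon would move the number clearly away from that of compound 3. As far as these compounds go, whether these steps would hold with a cyclopropyl group in place of the isopropyl on the shared core also remains open.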